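The compounds below may be only part of what the source reports. "The series", "measured", "known", "first", "only" and "open" are said of these compounds alone.

Measured so far:
compound 1, `Cc1cc(C)c2c(O)cc(-c3cccc4ccccc34)nc2n1`, 380 nM
compound 2, `Cc1cnc2nc(-c3ccc4ccccc4c3)cc(O)c2c1`, 468 nM

Two compounds share the core and have been run in a functional assay on HCT-116 cells (Homo sapiens) for antiproliferative activity; on this read-out lower numbers stand for stronger inhibition of growth and higher numbers for weaker inhibition of growth. Compound 1 gives 380 nM and compound 2 gives 468 nM; compound 1 has the lower of the two numbers, but its gap to compound 2 lies within the scatter, so the two cannot be told apart. Within the data shown here, no pair of measured compounds differs in only one place, so nothing measured shows how a single change moves the read-out.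

Compound 3, `Cc1ccnc2nc(-c3cccc4ccccc34)cc(O)c12`, is not yet measured. It differs from compound 1 in one place: hydrogen in place of methyl on an aromatic carbon. Among the measured compounds shown here, a single heavy atom leaves, with no change in donors, acceptors or charge, and with no measured single-place step to lean on, a step no larger than the scatter is expected in this assay, in no set direction. The expected step is a 1.2-fold higher number from compound 1 to compound 3 (0.07 log units; within the scatter). Compound 3 is therefore estimated at 450 nM, with a range from 200 nM to 1000 nM.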

Compound 3, concentration for 50% growth inhibition: < 10 nM
Compound 3 gave a limit, no number (the forecaster's own chance of this, stated with the estimate: 5%); middle value at least 45-fold (1.65 log units) from the limit.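

In this assay, among these compounds, hydrogen in place of methyl on the aromatic carbon next to the ring nitrogen gives an at least 38-fold lower number from compound 1 to compound 3 (1.57 log units; beyond the scatter), the first single-place step, and it shows that the read-out can respond strongly to the loss of one heavy atom at this position. Compound 3 gives < 10 nM, which is a limit of the assay and not a number. The step is therefore known only as a bound, and its full size stays unfixed: the limit of < 10 nM in this assay, at which 1 of the 3 values shown sits.

The compounds shown leave open whether an ethyl, a methoxy or an amine on this same carbon would read closer to compound 1 or to compound 3. They also leave open what the remaining methyl group, meta to this position, contributes to the read-out of compound 3.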